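The compounds below may be only part of what the source reports. "The series", "measured", "known", "first", "only" and "open" are said of these compounds alone.

Measured so far in a functional assay on OVCAR-8 cells (Homo sapiens) for antiproliferative activity; on this read-out lower numbers stand for stronger inhibition and higher numbers for weaker inhibition:
compound 1 `Cn1ncc(Cl)c1-c1cc(C(=O)N[C@@H]2CN[C@H](CC(=O)O)C[C@H]2c2ccc(Cl)c(Cl)c2)oc1Cl` — 5120 nM
compound 2 `CC(=O)OCC[C@@H]1C[C@@H](c2ccc(F)c(F)c2)[C@H](NC(=O)c2cc(-c3c(Cl)cnn3C)c(Cl)o2)CN1` — 4960 nM

Compound 1 gives the higher of the two numbers, but compound 2 lies within the scatter of it, so no order between the two can be read; both sit in the same weak region of this assay. Compound 3 `Cn1ncc(Cl)c1-c1cc(C(=O)N[C@@H]2CN[C@H](CC(=O)NC3CCC3)C[C@H]2c2ccc(Cl)c(Cl)c2)oc1Cl` is compound 1 with one change: cyclobutylamino in place of hydroxy on a carbonyl carbon. For the measured compounds named here, no step between measured compounds covers a change of this kind, so there is no measured step to lean on, and the expectation rests on the change alone. The expected direction is toward a lower number in this assay, with a step of modest size and wide uncertainty. Compound 3 is therefore expected at 1800 nM, with a range of 400 nM to 8000 nM, meaning an estimated step of a 2.8-fold lower number from compound 1 to compound 3 (0.45 log units; beyond the scatter).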

Compound 3, half-maximal inhibitory concentration: 610 nM
Beside the measured number, compound 3's estimate is 3.0-fold (0.47 log units) above it; the measured number falls inside the stated range.
By their numbers in this assay, from the lowest: compound 3; then compounds 2 and 1 (each within the scatter of the next).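

In this assay, the carbonyl carbon on the saturated chain proves to be a place where the series responds: cyclobutylamino in place of hydroxy gives an 8.4-fold lower number from compound 1 to compound 3 (0.92 log units; beyond the scatter). For the compounds shown here, this is the first step that can be read at a single place, and it shows that the carboxy group is not needed for activity here, since the cyclobutylcarbamoyl compound gives the lower number. No measured evidence on hand accounts for the size or direction of this step.

This single step cannot separate the loss of the hydroxy group from the arrival of the four-membered carbon ring. Methylamino, unsubstituted amino or cyclopentylamino on the same carbonyl carbon would show how much of the step depends on the cyclobutyl ring itself.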